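This account rests on a few compounds, and the source may have more. Where it says the series, first, only, none or still open, it means among the compounds named here.

Compound 1 `COc1cccc(NC(=O)C(Cl)Cl)c1` and compound 3 `COc1ccc(NC(=O)C(Cl)Cl)cc1` are built from the same atoms joined differently; the difference between the two cores is not broken down here. In a functional assay on KB cells (Homo sapiens) for antiproliferative activity, read by MTT assay, with a stated time of 72 h (a lower number here means a stronger inhibitor, a higher number a weaker inhibitor), compound 1 gives 57700 nM, and compound 3 gives 278000 nM. Compound 2 `O=C(Nc1cccc(SC(F)(F)F)c1)C(Cl)Cl` carries (trifluoromethyl)sulfanyl in place of methoxy on an aromatic carbon, a change that gives a 12-fold lower number from compound 1 to compound 2 (1.08 log units; beyond the scatter). In this assay compound 2 gives 4840 nM. Compound 4 `O=C(Nc1ccc(SC(F)(F)F)cc1)C(Cl)Cl` is not yet measured; it carries (trifluoromethyl)sulfanyl in place of methoxy on an aromatic carbon, the same kind of change, though its place is para to a group of 6 heavy atoms whereas in compound 2 it is meta to a group of 6 heavy atoms. Going by the values given here, a step of similar size is expected, because the only guide is a 12-fold lower number from compound 1 to compound 2 (1.08 log units; beyond the scatter), with some room for difference since the place is not the same. The expected step is an 11-fold lower number from compound 3 to compound 4 (1.05 log units; beyond the scatter). For compound 4 in this assay the estimate is 25000 nM, likely between 5000 nM and 110000 nM.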

Compound 4, half-maximal inhibitory concentration: 2080 nM
Estimate against measurement, compound 4: 12-fold (1.08 log units) above, outside the stated range (below it).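

In this assay, putting (trifluoromethyl)sulfanyl in place of methoxy gives a 130-fold lower number from compound 3 to compound 4 (2.13 log units; beyond the scatter). The number falls on both cores, but the size of the fall does not carry over from one core to the other: the same change on two cores in this assay, a 12-fold lower number (1.08 log units; beyond the scatter) from compound 1 to compound 2 and a 130-fold lower number (2.13 log units; beyond the scatter) from compound 3 to compound 4, 11-fold (1.05 log units) apart, beyond the scatter of two such steps. So in these two pairs the direction held while the size did not, and the pairs do not show why the sizes differ or whether the direction would hold on a further core.

The compounds shown leave open how an amine, a carboxylic acid or a longer chain in place of methoxy would compare. Going by these compounds alone, with only two pairs, they also leave open which of the two step sizes, if either, is the more typical for this change.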